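The source may hold more compounds than are shown below. What is called first, only, known or untested is meant among the compounds shown, and "the series" means these compounds.

Working notes on the series. The shared core of compound 1 `C=CCn1c(=O)/c(=C\c2cccc(Cl)c2)[nH]c(=O)/c1=C\c1ccccc1OC` carries, on a double-bonded chain carbon bound to an aromatic carbon, a varied aryl group, and in a functional assay on K562 cells (Homo sapiens) for cytotoxicity, read by CCK-8 assay, with a stated time of 72 h (on this read-out lower numbers stand for stronger inhibition and higher numbers for weaker inhibition), compound 1 gives 2700 nM. Compound 2 `C=CCn1c(=O)/c(=C\c2ccccc2C(F)(F)F)[nH]c(=O)/c1=C\c1ccccc1OC` gives 2700 nM in this assay, so no change at the digits printed from compound 1 to compound 2 (within the scatter). Compound 3 `C=CCn1c(=O)/c(=C\c2ccc(C)cc2)[nH]c(=O)/c1=C\c1ccccc1OC` was reported as "not active" (no number reported) in this assay, without a number; it stands apart from compound 1 and compound 2, which both returned numbers. Compound 4 `C=CCn1c(=O)/c(=C\c2cc(F)ccc2C)[nH]c(=O)/c1=C\c1ccccc1OC` is the next member. The change from compound 3 to compound 4 is 5-fluoro-2-methylphenyl in place of 4-methylphenyl on a double-bonded chain carbon bound to an aromatic carbon. Among the compounds with values here, no measured step covers this change directly; the only measured step, from compound 1 to compound 2, shows that exchanging one aryl group for another can leave this assay unchanged within the scatter, while compound 3 shows that another such exchange can remove measurable activity. The starting point for compound 4 has no number, so the expectation rests on where compound 1 and compound 2 stand, with a wide range and a real chance that compound 4 again returns no number. For compound 4 the estimate in this assay is 4500 nM, expected to lie between 1500 nM and 25000 nM.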

Compound 4, half-maximal inhibitory concentration: 1800 nM
The estimate for compound 4 lay 2.5-fold (0.40 log units) above the measured number; the range from low to high includes it.
By their numbers in this assay, from the lowest: compounds 4, 1 and 2 (each within the scatter of the next).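

In this assay the steps of a 1.5-fold lower number from compound 2 to compound 4 (0.18 log units; within the scatter) and a 1.5-fold lower number from compound 1 to compound 4 (0.18 log units; within the scatter) place compound 4 with the compounds that return numbers, so three different aryl groups at this place now give values within the scatter of one another. A methyl on the aryl group therefore does not by itself go with the missing number, since compound 3, with 4-methylphenyl, has none, while compound 4, with 5-fluoro-2-methylphenyl, gives 1800 nM in this assay. No supporting measurement accounts for this difference between compound 3 and compound 4.

The compounds shown do not separate the fluorine from the position of the methyl in that difference. Also open, from the compounds shown here alone, is whether an aryl group carrying an amine or a carboxylic acid, or a longer chain in place of the aryl group, would return a number here.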